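Bromo added to an inactive triazole series

The source may report more compounds than this note shows. Statements on the series, on what has been measured and on what is new or still open speak of the compounds shown alone.

Measured compounds and values:
compound 1 `C=C1C[C@]23C[C@@]1(O)CC[C@H]2c1ccc(O)c(C)c1[C@@H]3Cn1cc(-c2ccccn2)nn1`: > 20000 nM
compound 2 `C=C1C[C@]23C[C@@]1(O)CC[C@H]2c1cc(Br)c(O)c(C)c1[C@@H]3Cn1cc(-c2ccccn2)nn1`: > 20000 nM
compound 3 `C=C1C[C@]23C[C@@]1(O)CC[C@H]2c1ccc(O)c(C)c1[C@@H]3Cn1cc(-c2ccc(C)cc2)nn1`: > 20000 nM

All three were tested in a functional assay on MCF7 cells (Homo sapiens) for cytotoxicity, read by MTT assay, with a stated time of 4 days; on this read-out higher numbers stand for weaker inhibition and lower numbers for stronger inhibition. In this assay compound 1 gives only a limit, > 20000 nM. Compound 2 likewise gives only a limit, > 20000 nM. Compound 3 too gives only a limit, > 20000 nM. Thus (the limit of > 20000 nM in this assay, at which 3 of the 3 values shown sit).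

The change from compound 1 to compound 2 is bromo in place of hydrogen on an aromatic carbon. Its step, a step that the two limits leave unreadable from compound 1 to compound 2, cannot be sized because of the limit of > 20000 nM in this assay, at which 3 of the 3 values shown sit. The two cores differ by 4-methylphenyl in place of pyridin-2-yl on an aromatic carbon, and that step, a step that the two limits leave unreadable from compound 1 to compound 3, is equally unreadable.

Compound 4, `C=C1C[C@]23C[C@@]1(O)CC[C@H]2c1cc(Br)c(O)c(C)c1[C@@H]3Cn1cc(-c2ccc(C)cc2)nn1`, carries the same change as compound 2: bromo in place of hydrogen on an aromatic carbon. Since compound 3 sits at a limit (> 20000 nM) and compound 2 stayed at a limit (> 20000 nM), the step that the limit leaves unreadable from compound 3 to compound 4 is expected to be flat. Compound 4 is therefore expected to give about 40000 nM, most likely reported as a limit.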

Compound 4, half-maximal inhibitory concentration: > 20000 nM
Compound 4 was reported as a limit; the forecaster's own chance of this, stated with the estimate: 85%; the middle value is on the limit's open side.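

No step from compound 3 or compound 2 to compound 4 can be read, because all these values are limits: the limit of > 20000 nM in this assay, at which 4 of the 4 values shown sit.

The compounds shown leave open how strongly any of these compounds, with or without bromo, acts in this assay.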